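This account rests on a few compounds, and the source may have more. Where it says the series, first, only, none or still open, it means among the compounds named here.

Measured so far in a functional assay on DU-145 cells (Homo sapiens) for inhibition, read by MTT assay, with a stated time of 24 h; a higher number here means a weaker inhibitor, a lower number a stronger inhibitor:
- compound 1 `CCOC(=O)C1=Cc2ccccc2OC1(OCc1cn(CC(=O)Nc2ccc(OC)cc2)nn1)C(F)(F)F`: 32700 nM
- compound 2 `CCOC(=O)C1=Cc2ccccc2OC1(OCc1cn(CC(=O)Nc2ccccc2F)nn1)C(F)(F)F`: 33900 nM

Compound 2 gives the highest of the two numbers, with compound 1 nearest; the step of a 1.0-fold higher number from compound 1 to compound 2 (0.02 log units; within the scatter) lies within the scatter. Compound 3 `CCOC(=O)C1=Cc2ccccc2OC1(OCc1cn(CC(=O)Nc2ccc(I)cc2Cl)nn1)C(F)(F)F` differs from compound 2 by 2-chloro-4-iodophenyl in place of 2-fluorophenyl on an amide-type nitrogen. Going by the values given here, the only comparable step, an exchange of the aryl group on the same amide-type nitrogen, from compound 1 to compound 2, gave no change beyond the scatter, so for compound 3 the step of a 1.1-fold lower number from compound 2 to compound 3 (0.05 log units; within the scatter) in this assay is expected to stay within the scatter. Compound 3 is estimated at 30000 nM, range 12000 nM to 80000 nM.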

Compound 3, half-maximal inhibitory concentration: 24400 nM
Compound 3: middle estimate off by 1.2-fold (0.09 log units), on the high side, within the range that was stated.
By their numbers in this assay, from the lowest: compounds 3, 1 and 2 (each within the scatter of the next).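

In this assay, the amide-type nitrogen now also carries 2-chloro-4-iodophenyl, with two halogens on the ring, and both steps to it stay within the scatter (a 1.4-fold lower number from compound 2 to compound 3 (0.14 log units; within the scatter); a 1.3-fold lower number from compound 1 to compound 3 (0.13 log units; within the scatter)). The 4-methoxyphenyl, 2-fluorophenyl and 2-chloro-4-iodophenyl groups therefore cannot be told apart at this position in this assay. No evidence is available that bears on this result.

Open, going by these compounds, is whether a phenyl ring carrying an amine or a carboxylic acid, or a cyclohexyl group in place of the aryl ring, moves the number beyond the scatter.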